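The source may hold more compounds than are shown below. What is called first, only, known or untested is meant among the compounds shown, and "the series" means these compounds.

In a functional assay on HCT-116 cells (Homo sapiens) for antiproliferative activity, read by MTT assay, with a stated time of 24 h (a lower number here means a stronger inhibitor, a higher number a weaker inhibitor), compound 1 `COc1ccc(C(=O)/C=C/c2ccc(-n3ccnc3)cc2)c2c1C=CC(C)(C)O2` gives > 10000 nM, which is a limit of the assay and not a number. Compound 2 `COc1ccc(C(=O)/C=C/c2cccc(Cl)c2)c2c1C=CC(C)(C)O2` gives > 10000 nM, also a limit, so its position is known only as the limit of > 10000 nM in this assay, at which 2 of the 2 values shown sit. Compound 3 `COc1ccc(C(=O)/C=C/c2ccc(O)cc2)c2c1C=CC(C)(C)O2` has 4-hydroxyphenyl in place of 3-chlorophenyl on a double-bonded chain carbon bound to a double-bonded chain carbon. Going by the values given here, no measured step shows what such a swap does, so no step beyond the usual scatter is expected, and the estimated change is a step that the limit leaves unreadable from compound 2 to compound 3. For compound 3, the expected value is 12000 nM, within an estimated range of 4000 nM to 30000 nM.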

Compound 3, half-maximal inhibitory concentration: > 10000 nM
Compound 3 was reported as a limit (the forecaster's own chance of this, stated with the estimate: 65%); the middle value lies beyond the limit too.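

Compound 3 ends up like compound 1 and compound 2, so no step among the three can be read: the limit of > 10000 nM in this assay, at which 3 of the 3 values shown sit.

Still open, going by these compounds, is how strongly each acts in this assay, and whether 4-hydroxyphenyl and 3-chlorophenyl differ there at all.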